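Bromo for Chloro: Carrying One Measured Step to Compound 4

This account rests on a few compounds, and the source may have more. Where it says the series, first, only, none or still open, it means among the compounds named here.

Compound 1 `O=C(CSc1nc(Nc2ccccc2)c2ccccc2n1)Nc1ccccc1Cl` and compound 2 `O=C(CSc1nc(Nc2ccccc2)c2ccccc2n1)Nc1ccccc1Br` share one core and differ in a single place. In a functional assay on MDA-MB-231 cells (Homo sapiens) for inhibition, read by MTT assay, with a stated time of 72 h (a lower number here means a stronger inhibitor, a higher number a weaker inhibitor), compound 1 gives 24400 nM. In this assay compound 2 gives 14100 nM. The change between them is bromo in place of chloro on an aromatic carbon, and it made a 1.7-fold lower number from compound 1 to compound 2 (0.24 log units; within the scatter).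

Compound 3 `C=CC(=O)Nc1cccc(NC(=O)CSc2nc(Nc3ccccc3Cl)c3ccccc3n2)c1` is built on a second core. The difference between the two cores is not broken down here. In this assay compound 3 gives 12700 nM, and the numbers from compound 2 and compound 3 lie within the scatter of each other, as do those from compound 1 and compound 3.

Compound 4 `C=CC(=O)Nc1cccc(NC(=O)CSc2nc(Nc3ccccc3Br)c3ccccc3n2)c1` has not yet been measured. It relates to compound 3 as compound 2 relates to compound 1: the change is bromo in place of chloro on an aromatic carbon. The surroundings of the place are described in the same words in both pairs, so this is the same change, now applied on the second core.

Among the compounds with values here, only one earlier instance of the change is available, and it stayed within the scatter. On that basis the step from compound 3 to compound 4 in this assay is expected to be a 1.4-fold lower number from compound 3 to compound 4 (0.15 log units; within the scatter), resting on compound 1 and compound 2, which showed a 1.7-fold lower number from compound 1 to compound 2 (0.24 log units; within the scatter). For compound 4 the estimate in this assay is 9000 nM, with a range from 4000 nM to 20000 nM.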

Compound 4, half-maximal inhibitory concentration: 15200 nM
Compound 4: the middle estimate sits 1.7-fold (0.23 log units) below what was measured; low and high end bracket the measured number.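

In this assay, bromo in place of chloro on an aromatic carbon of the second core gave a 1.2-fold higher number from compound 3 to compound 4 (0.08 log units; within the scatter), so the swap again left the number within the usual scatter of repeated measurements. Set beside the earlier instance, the two steps point in opposite directions on paper, yet they cannot be told apart: the same change on two cores in this assay, a 1.7-fold lower number (0.24 log units; within the scatter) from compound 1 to compound 2 and a 1.2-fold higher number (0.08 log units; within the scatter) from compound 3 to compound 4, 2.1-fold (0.32 log units) apart, within the scatter of two such steps. This shows that, in these two pairs, exchanging chloro for bromo did not shift the read-out beyond the scatter on either core and that the core made no visible difference to the step, but it does not show that the change has a real effect of its own in either direction, that the two cores respond alike to it in any finer sense, or that the same would hold on any further core.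

The compounds shown carry only chloro or bromo in this place, so it remains open whether a fluoro, a methyl, a methoxy or an amine there would move the number beyond the scatter. Within the data shown here, it also remains open whether any such replacement would behave the same way on both cores, since the only comparison available so far rests on a single pair from each.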